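The compounds below may be only part of what the source reports. "The series", "measured", "known", "first", "only" and "open" are said of these compounds alone.

Compound 1 `Cc1cc(Nc2cc(-c3ccccc3)[nH]n2)n2ncnc2n1` is the weakest of the three compounds measured in a functional assay on MGC-803 cells (Homo sapiens) for inhibition, read by MTT assay, with a stated time of 72 h (a higher number here means a weaker inhibitor, a lower number a stronger inhibitor), and compound 1 gives 21700 nM in that assay. Compound 2 `Cc1cc(Nc2cc(-c3cccs3)[nH]n2)n2nc(SCc3ccc(Br)cc3)nc2n1` differs from compound 1 in more than one place and in this assay compound 2 gives 3770 nM, a lower number that lies beyond the scatter. Compound 3 `Cc1cc(Nc2ccn(Cc3ccc(F)cc3)n2)n2nc(SCc3ccc(Br)cc3)nc2n1` likewise differs from compound 1 in more than one place, and in this assay compound 3 gives 3070 nM, again beyond the scatter relative to compound 1. Compound 4 `Cc1cc(Nc2cc(-c3ccccc3)[nH]n2)n2nc(SCC3CCCCC3)nc2n1` has not yet been measured. It differs from compound 1 in a single place: (cyclohexylmethyl)sulfanyl in place of hydrogen on an aromatic carbon. Among the measured compounds shown here, no measured pair shows this exact change on its own, so the expected size of the step rests on the comparison of compound 1 with compound 2 and compound 3, both of which carry additional substitution on the shared core and both of which give lower numbers. The step from compound 1 to compound 4 is expected to be a decrease, a 4.3-fold lower number from compound 1 to compound 4 (0.64 log units; beyond the scatter), beyond the scatter. Compound 4 is therefore estimated at 5000 nM, within a range of 1500 nM to 16000 nM.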

Compound 4, half-maximal inhibitory concentration: 12600 nM
The estimate for compound 4 lay 2.5-fold (0.40 log units) below the measured number, within the range that was stated.
By their numbers in this assay, from the lowest: compounds 3 and 2 (each within the scatter of the next); then compounds 4 and 1 (each within the scatter of the next).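

Placed on an aromatic carbon of the five-membered aromatic ring with 3 nitrogen, (cyclohexylmethyl)sulfanyl gives the first reading of a change at this position alone, and in this assay the step is a 1.7-fold lower number from compound 1 to compound 4 (0.24 log units; within the scatter). Compound 2 and compound 3 each differ from compound 1 in more than one place and could not show this: the substituent on its own, with its six-membered non-aromatic ring of carbon only, does not separate the two compounds beyond the scatter. Nothing measured here gives a reason for this result.

The compounds shown leave open whether an amine, a carboxylic acid or a methylsulfanyl group at this position would move the number beyond the scatter. They also leave open how much of the lower numbers of compound 2 and compound 3, each of which differs from compound 1 in more than one place, belongs to this position.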